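This account rests on a few compounds, and the source may have more. Where it says the series, first, only, none or still open, it means among the compounds named here.

Compound 1, with the structure `COc1cc(NCc2ccc(Cl)s2)ccc1-c1cnco1`, was tested in an ADME assay on Huh-7 cells (Homo sapiens) for cytotoxicity, read by MTT assay, with a stated time of 96 h (a lower number here means that less compound is tolerated, a higher number that more compound is tolerated), where compound 1 gives 43200 nM. Compound 2, `COc1ccc(CNc2ccc(-c3cnco3)c(OC)c2)cc1`, shares the core and gives 41300 nM in the same assay. These two numbers lie within the usual scatter of each other, so neither can be called better tolerated than the other. Compound 3, `COc1ccc(-c2cnco2)cc1NCc1cccs1`, gives only a limit, > 100000 nM, and not a number. That limit, (the limit of > 100000 nM in this assay, at which 1 of the 3 values shown sits), is the edge of what this assay can report.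

Compound 4, `CCc1ccc(CNc2ccc(-c3cnco3)c(OC)c2)s1`, has not yet been measured. It differs from compound 1 in one place: ethyl in place of chloro on an aromatic carbon. Within the data shown here, no measured pair among the three compounds above shows what such an exchange does to tolerability, so the expectation rests on how close compound 1 and compound 2 sit. The step from compound 1 to compound 4 is expected to be small, a 1.2-fold higher number from compound 1 to compound 4 (0.06 log units; within the scatter), and not beyond the scatter in either direction. Compound 4 is therefore estimated to give 50000 nM in this assay, with a range from 22000 nM to 100000 nM.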

Compound 4, half-maximal cytotoxic concentration: 39100 nM
Beside the measured number, compound 4's estimate is 1.3-fold (0.11 log units) above it; the range from low to high includes it.
By their numbers in this assay, from the lowest: compounds 4, 2 and 1 (each within the scatter of the next). At a limit, above all of these: compound 3.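

On the carbon next to the ring sulfur, the exchange of chloro for ethyl now has a measured result: in this assay it gives a 1.1-fold lower number from compound 1 to compound 4 (0.04 log units; within the scatter) and so cannot be told apart from no change at all. The earlier compounds shown here held no such pair, and this one shows that the chlorine is not needed at this place for the number to stay where it is, and that a group of two carbons is tolerated there just as the single chlorine atom is. Among these compounds, nothing measured so far explains why these two groups read alike.

From the compounds shown here alone, a single exchange says little about groups of a different kind, so it remains open whether an amine, a carboxylic acid or a longer chain such as butyl on the same carbon would stay within the scatter of compound 1 or move clearly away from it. Among the compounds shown here, it is also open whether chloro and ethyl would read alike on a different core, as only one pair of compounds carries this exchange.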